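The source may hold more compounds than are shown below. What is called first, only, known or untested is meant among the compounds shown, and "the series" means these compounds.

Measured so far, in a functional assay on CHO cells for antagonist activity at corticotropin-releasing factor receptor 1 (Homo sapiens), read by cAMP accumulation; a higher number here means a weaker inhibitor, a lower number a stronger inhibitor:

Compound 1 `COc1ccc(-n2c(C)nc3c(NC(C4CC4)C4CC4)nc(C)nc32)cc1` gives 19 nM.
Compound 2 `COCc1nc2c(NC(C3CC3)C3CC3)nc(C)nc2n1-c1ccc(OC)cc1` gives 157 nM.
Compound 3 `COc1ccc(-n2c(C3CC(F)(F)C3)nc3c(NC(C4CC4)C4CC4)nc(C)nc32)cc1` gives 261 nM.

Compound 1 has the lowest number of the three, and both of its steps to the others lie beyond the scatter: an 8.3-fold higher number from compound 1 to compound 2 (0.92 log units; beyond the scatter) and a 14-fold higher number from compound 1 to compound 3 (1.14 log units; beyond the scatter). Between the other two the gap is small, a 1.7-fold higher number from compound 2 to compound 3 (0.22 log units; within the scatter), so nothing can be said of their order.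

Compound 4 `Cc1nc(NC(C2CC2)C2CC2)c2nc(C)n(-c3ccc(F)cc3)c2n1` has not yet been measured in this assay. It differs from compound 1 in one place: fluoro in place of methoxy on an aromatic carbon. This change sits on the phenyl ring, whereas the two measured steps from compound 1 both alter the group on the five-membered ring of the shared core. Among the compounds with values here, no measured step therefore bears directly on the change from compound 1 to compound 4, and the data give no guidance on its direction. With nothing to point either way, the expectation is a step of no more than modest size from compound 1 to compound 4, a 1.6-fold higher number from compound 1 to compound 4 (0.20 log units; within the scatter), most likely within the scatter. Compound 4 is estimated at 30 nM, with a range from 10 nM to 90 nM.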

Compound 4, inhibition constant: 91 nM
Estimate against measurement, compound 4: 3.0-fold (0.48 log units) below; measured number above the stated range.
By their numbers in this assay, from the lowest: compound 1; then compounds 4, 2 and 3 (each within the scatter of the next, the first and the last beyond it).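

In this assay, putting fluoro in place of methoxy on the six-membered aromatic ring gives a 4.8-fold higher number from compound 1 to compound 4 (0.68 log units; beyond the scatter) and so shows that this position, which stayed the same in compounds 1, 2 and 3, also affects the result. The swap is small on paper, with one heavy atom fewer and one hydrogen-bond acceptor fewer, yet its step lies beyond the scatter, so methoxy is the better of the two groups seen at this place. Nothing available here explains why the number rises with this change.

As far as these compounds go, with only methoxy and fluoro to compare at this position, it remains open how a group such as ethoxy, chloro or an amine would behave, and so whether methoxy is close to the best choice or just one point in a wider range. From the compounds shown here alone, it is also open whether the same swap would have a similar effect in compounds 2 and 3, which carry methoxymethyl and 3,3-difluorocyclobutyl in place of the methyl of compound 1.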